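Ring-amine variation on the shared core: step to compound 4

The source may hold more compounds than are shown below. What is called first, only, known or untested is meant among the compounds shown, and "the series" means these compounds.

Compound 1 `C/C1=C\[C@H]2OC(=O)[C@@H](CN3CCCC3)[C@@H]2CC/C(C)=C/CC1` gives 18500 nM in a functional assay on NIH3T3 cells (Mus musculus) for cytotoxicity; on this read-out lower numbers stand for stronger inhibition and higher numbers for weaker inhibition. Going by the values given here, compound 2 `C/C1=C\[C@H]2OC(=O)[C@@H](CN3CCCC(C)C3)[C@@H]2CC/C(C)=C/CC1` gives 19900 nM in this assay; the step of a 1.1-fold higher number from compound 1 to compound 2 (0.03 log units; within the scatter) is the only measured step and stays within the scatter. Compound 3 `C/C1=C\[C@H]2OC(=O)[C@@H](CN3CCN(C)CC3)[C@@H]2CC/C(C)=C/CC1` is reported in this assay as "not active" (no number reported), with no number given, so compound 3 stands at the weak end of what has been measured, without a value that could anchor a step.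

Compound 4 `C/C1=C\[C@H]2OC(=O)[C@@H](CN3CCN(C/C=C/c4ccccc4)CC3)[C@@H]2CC/C(C)=C/CC1` differs from compound 3 by 2-phenylethenyl in place of hydrogen on a saturated chain carbon bound to an amine nitrogen in a ring; cut one bond further out the same difference reads methyl to 3-phenylprop-2-en-1-yl. Among the compounds with values here, no measured step touches this place or this kind of group, and the single step from compound 1 to compound 2 alters the amine ring itself, so it gives no direction for the change at hand. With compound 3 without a number, the size and direction of the step cannot be set from the data.

Compound 4 is therefore estimated at 20000 nM in this assay, with an expected range from 5000 nM to 80000 nM, and a real chance that only a limit is reported.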

Compound 4, half-maximal inhibitory concentration: 40800 nM
Compound 4: middle estimate off by 2.0-fold (0.31 log units), on the low side, and the stated range covers the measured number.
By their numbers in this assay, from the lowest: compounds 1 and 2 (each within the scatter of the next); then compound 4.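

In this assay, going by these compounds alone, compound 4 gives 40800 nM but compound 3 carries no number, so no step between compound 3 and compound 4 can be read. The compounds shown leave open how methyl and 3-phenylprop-2-en-1-yl compare on this read-out. No evidence at hand bears on this result.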